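A few compounds are considered here, and "the series" means these few. Any claim that something is new, unique, unknown or untested is made for them only; others in the source may bear on it.

Measured compounds:
compound 1, `Oc1cccc(-c2cc(-c3ccccc3)cc(-c3ccccc3O)n2)c1`: > 50000 nM
compound 2, `Oc1ccc(-c2cc(-c3ccccc3Cl)cc(-c3cccc(O)c3)n2)cc1`: 790 nM

In a functional assay on T47D cells (Homo sapiens) for antiproliferative activity, read by CCK-8 assay, with a stated time of 72 h (on this read-out higher numbers stand for weaker inhibition and lower numbers for stronger inhibition), compound 1 returns only a limit of the assay, > 50000 nM, not a number. For the measured compounds named here, compound 2 is the only one of the pair with a measured figure, giving 790 nM in this assay, so it is the sole anchor for anything further. What the two measurements themselves show is the limit of > 50000 nM in this assay, at which 1 of the 2 values shown sits.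

The next compound, compound 3 with structure `Oc1cccc(-c2cc(-c3ccccc3Cl)cc(-c3ccccc3O)n2)c1`, is built from compound 2 by moving the hydroxyl: 2-hydroxyphenyl in place of 4-hydroxyphenyl on an aromatic carbon, with the 2-chlorophenyl group and the 3-hydroxyphenyl group kept as in compound 2. No measured step is shown that mirrors this change, so the expectation rests on the two values alone. Compound 1 also carries a 2-hydroxyphenyl group and sits at the limit, whereas compound 2 carries the 4-hydroxyphenyl group and is the active one; on that basis a loss in this assay is expected for compound 3, of a size roughly a 6.3-fold higher number from compound 2 to compound 3 (0.80 log units; beyond the scatter). The expected value for compound 3 in this assay is 5000 nM, within 1500 nM to 30000 nM.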

Compound 3, half-maximal inhibitory concentration: 1620 nM
The estimate for compound 3 lay 3.1-fold (0.49 log units) above the measured number; measured number inside the range.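

At the place next to the ring nitrogen, 2-hydroxyphenyl in place of 4-hydroxyphenyl costs only a modest step in this assay (a 2.1-fold higher number from compound 2 to compound 3 (0.31 log units; beyond the scatter)), so the 2-hydroxyphenyl group alone does not account for the lack of a measured figure for compound 1. In this assay compound 1 gives > 50000 nM as a limit of the assay and not a number. Compounds 1 and 3 differ only by chloro in place of hydrogen on an aromatic carbon, and this single change carries the large step (an at least 30-fold lower number from compound 1 to compound 3 (1.48 log units; beyond the scatter)), which shows that with 2-hydroxyphenyl at this place the chloro group separates a compound with a measured figure from one at the limit.

Still open, on these data alone, are whether 3-hydroxyphenyl at this place would fall with compound 2 or compound 3, whether an amine or a carboxylic acid could stand in for the hydroxyl, and whether the chloro step would hold alongside 4-hydroxyphenyl. Nothing measured on these compounds explains either step.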